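Nitro for methoxy on the fused bicyclic core

The source may report more compounds than this note shows. Statements on the series, on what has been measured and on what is new or still open speak of the compounds shown alone.

Measured so far:
compound 1 `O=c1[nH]c2ccc(O)cc2oc1=O`, 170000 nM
compound 2 `COc1ccc2oc(=O)c(=O)[nH]c2c1`, 15000 nM
compound 3 `COC(=O)c1cc(OC)c2oc(=O)c(=O)[nH]c2c1`, 3400 nM

In a functional assay with Rattus norvegicus as the target (on this read-out lower numbers stand for stronger inhibition and higher numbers for weaker inhibition), compound 2 gives 15000 nM, the second highest of the three numbers. Its nearest neighbour is compound 3, whose value of 3400 nM lies beyond the scatter on the lower side; compound 1, with 170000 nM, lies furthest away, again beyond the scatter, on the higher side. Going by the values given here, none of the three pairs differs in only one place, so no single step between measured compounds can be read off.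

Compound 4 `O=c1[nH]c2cc([N+](=O)[O-])ccc2oc1=O` has not been measured. It differs from compound 2 as follows: nitro in place of methoxy on an aromatic carbon. Among the compounds with values here, nothing in the measured set bears a nitro group, so there is no measured step from which the effect of this exchange could be taken. The expectation for this assay is therefore a step that stays within or only slightly beyond the scatter, in either direction; the estimate places it as a 1.3-fold lower number from compound 2 to compound 4 (0.10 log units; within the scatter). Compound 4 is estimated at 12000 nM, with a range from 3000 nM to 50000 nM.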

Compound 4, half-maximal inhibitory concentration: 800 nM
Estimate against measurement, compound 4: 15-fold (1.18 log units) above; measured number below the stated range.
By their numbers in this assay, from the lowest: compound 4; then compound 3; then compound 2; then compound 1.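

In this assay, going by these compounds alone, nitro in place of methoxy on this aromatic carbon gives a 19-fold lower number from compound 2 to compound 4 (1.27 log units; beyond the scatter), a large step beyond the scatter and the first single-place change that can be read. Since lower numbers stand for stronger inhibition here, the substituent on this carbon, para to a fused ring and meta to a fused ring, clearly matters for the read-out, and nitro is the better of the two groups compared at this place. Nothing available explains the size of this step, and a single exchange cannot tell which feature of the entering group accounts for it.

Going by these compounds, it remains open whether this gain belongs to nitro itself or would also appear with an amine, a nitrile or a carboxylic acid on the same carbon, and how a bare hydrogen there would compare with both methoxy and nitro. Also open, on these data alone, is whether nitro would give a step of similar size on another carbon of the same aromatic ring, or alongside the methyl ester carried by compound 3.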